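Pyridine N-oxide piperidine acetamides: anilide ring substitution

The source may hold more compounds than are shown below. What is called first, only, known or untested is meant among the compounds shown, and "the series" means these compounds.

Working notes on a small set of piperidinyl acetamides. Compound 1 `Cc1cc(C)cc(NC(=O)CN2CCC(c3cccc[n+]3[O-])CC2)c1` carries a 3,5-dimethylphenyl group on the amide nitrogen and, in a functional assay on HEK293 cells for agonist activity at D(4) dopamine receptor (Homo sapiens), read by FLIPR (on this read-out higher numbers stand for an effect only at larger amounts of compound and lower numbers for an effect already at smaller amounts), compound 1 gives 52 nM. Compound 2 `Cc1cccc(NC(=O)CN2CCC(c3ccc(O)cc3)CC2)c1`, with a hydroxyphenyl group in place of the pyridine N-oxide, gives 70 nM in this assay, which lies within the scatter of compound 1. Compound 3 `COc1cccc(C(=O)NCN2CCC(c3cccc[n+]3[O-])CC2)c1C`, with a different linker between the amide and the piperidine, gives 685 nM in this assay, a number beyond the scatter above that of compound 1. Compound 1 therefore stands at the low end of the numbers seen so far, with compound 2 close to it and compound 3 well apart.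

Compound 4 `Cc1ccc(Cl)cc1NC(=O)CN1CCC(c2cccc[n+]2[O-])CC1` has not yet been measured in this assay. The change from compound 1 is 5-chloro-2-methylphenyl in place of 3,5-dimethylphenyl on an amide-type nitrogen. Among the compounds with values here, no pair of measured compounds differs only in the anilide ring, so the size of this step cannot be read from the data. Expected for compound 4 is 90 nM, with a range from 30 nM to 300 nM. The step of a 1.7-fold higher number from compound 1 to compound 4 (0.24 log units; within the scatter) is expected to be small, a modest rise in the number that may still fall within the scatter.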

Compound 4, half-maximal effective concentration: 126 nM
Compound 4: the middle estimate sits 1.4-fold (0.15 log units) below what was measured; the range from low to high includes it.
By their numbers in this assay, from the lowest: compounds 1, 2 and 4 (each within the scatter of the next, the first and the last beyond it); then compound 3.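

Within the data shown here, replacing 3,5-dimethylphenyl with 5-chloro-2-methylphenyl on an amide-type nitrogen gives the first readable step: in this assay there is a 2.4-fold higher number from compound 1 to compound 4 (0.38 log units; beyond the scatter), so the number responds to the substitution of this ring, though only modestly. The leaving and entering groups have the same heavy-atom count, and neither has hydrogen-bond donors or acceptors, so these counts do not separate two groups whose values differ beyond the scatter. No measurement available here bears on why the number rises.

Among these compounds, with chlorine and the altered methyl pattern changing together, this one step cannot assign the rise to either feature, and no other step in the set can be read, since compounds 2 and 3 each differ from the others in more than one place. Also open, as far as these compounds go, is how the number would respond to a methoxy group, a nitrile, a primary amine or a carboxylic acid on the anilide ring, and whether any such step would hold with the hydroxyphenyl group of compound 2 in place of the pyridine N-oxide.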